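Fluorophenyl for trifluoromethylphenyl: outlook for compound 4

A few compounds are considered here, and "the series" means these few. Any claim that something is new, unique, unknown or untested is made for them only; others in the source may bear on it.

Measured so far in a functional assay on the whole organism (strain CD1) with Mus musculus as the target, in the maximal electroshock model, with a stated time of 4 h; a higher number here means that more compound is needed for the effect, a lower number that less compound is needed:
- compound 1 `O=C1NC(c2ccccc2)(c2ccccc2)C(=O)N1CN1CCN(c2cccc(C(F)(F)F)c2)CC1` gives 100 mg/kg
- compound 2 `CC(C)C1(C(C)C)NC(=O)N(CN2CCN(c3cccc(C(F)(F)F)c3)CC2)C1=O` gives 100 mg/kg
- compound 3 `CC(C)C1(C(C)C)NC(=O)N(CN2CCN(c3ccc(F)cc3)CC2)C1=O` gives 100 mg/kg
- compound 4 `O=C1NC(c2ccccc2)(c2ccccc2)C(=O)N1CN1CCN(c2ccc(F)cc2)CC1` is not yet measured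

Compound 1 stands level with compounds 2 and 3 in this assay; its nearest neighbour is compound 2 and its furthest is compound 3, and neither gap goes beyond the scatter, so no order among the three can be read from these numbers.

The change from compound 1 to compound 4 is 4-fluorophenyl in place of 3-(trifluoromethyl)phenyl on an amine nitrogen in a ring. Going by the values given here, one measured step bears directly on it: the same exchange carried out on the core of compound 2 gives no change at the digits printed from compound 2 to compound 3 (within the scatter), that is, no movement beyond the scatter. Nothing in the three values separates the diphenyl core of compound 1 from the diisopropyl core of compound 2, so the same outcome is expected here.

Compound 4 is therefore expected to show no change at the digits printed from compound 1 to compound 4 (within the scatter), essentially no step beyond the scatter. The estimate for compound 4 in this assay is 100 mg/kg, with a range from 50 mg/kg to 200 mg/kg.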

Compound 4, minimum effective dose: 100 mg/kg
Estimate against measurement, compound 4: no gap at the digits printed; the range from low to high includes it.
By their numbers in this assay, from the lowest: compounds 1, 2, 3 and 4 (each within the scatter of the next).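

In this assay, 4-fluorophenyl in place of 3-(trifluoromethyl)phenyl on an amine nitrogen in a ring gives no change at the digits printed from compound 1 to compound 4 (within the scatter). Until now this exchange could be read on the core of compound 2 alone; it can now be read on a second core, and within these four compounds the core carrying the exchange makes no visible difference to its outcome. The two readings of the exchange agree: the same change on two cores in this assay, no change at the digits printed (within the scatter) from compound 2 to compound 3 and no change at the digits printed (within the scatter) from compound 1 to compound 4, 1.0-fold (0.00 log units) apart, within the scatter of two such steps

As far as these compounds go, both aryl groups here are single carbon-only aromatic rings bearing fluorine, so what a phenyl carrying an amine or a carboxylic acid, or a longer chain in place of the aromatic ring, would do at this nitrogen stays open. From the compounds shown here alone, it also stays open whether any change at this place can shift the dose away from that of compound 1 at 100 mg/kg.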